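The source may report more compounds than this note shows. Statements on the series, on what has been measured and on what is new or still open speak of the compounds shown alone.

Measured so far:
compound 1 `Cc1oc(-c2c(F)cccc2F)nc1CN1CCC(C(=O)NCCCN2C[C@H](C)C[C@H](C)C2)CC1` - > 72 ug/mL
compound 2 `CCCN(CCC)CCNC(=O)C1CCN(Cc2nc(-c3ccccc3C)oc2C)CC1` - > 65 ug/mL

In a physicochemical assay for solubility, in phosphate buffer, measured as kinetic solubility, at pH 7.4 (on this read-out higher numbers stand for higher solubility and lower numbers for lower solubility), compound 1 stands at a limit, not a number (> 72 ug/mL). Compound 2 likewise gives only a limit (> 65 ug/mL). Compound 3 `Cc1cccc(F)c1-c1nc(CN2CCC(C(=O)NCCCN3C[C@H](C)C[C@H](C)C3)CC2)c(C)o1` carries methyl in place of fluoro on an aromatic carbon, so 2,6-difluorophenyl becomes 2-fluoro-6-methylphenyl. Within the data shown here, no measured step covers this change, and no step beyond the scatter is expected in this assay. The estimated step (an at least 1.0-fold lower number from compound 1 to compound 3 (0.01 log units; that floor lies within the scatter)) is expected to stay within the scatter. For compound 3 the expected value is 70 ug/mL (estimated range 35 ug/mL to 110 ug/mL).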

Compound 3, solubility: > 72 ug/mL
Compound 3: only a limit was reported; the forecaster's own chance of this, stated with the estimate: 65%; middle value at least 1.0-fold (0.01 log units) away from the limit.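

Compound 1 and compound 3 each give only a limit in this assay, so no step can be read between them. The compounds shown leave open whether methyl in place of fluoro on an aromatic carbon changes this read-out at all.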